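The source may hold more compounds than are shown below. What is called first, only, known or untested is meant among the compounds shown, and "the series" means these compounds.

Measured so far:
compound 1 `Cc1noc(-c2nc(C)c3c(c2N)C(=O)N(Cc2ccc(Oc4ccc(F)cc4)cc2)C3=O)n1`, 23800 nM
compound 2 `Cc1noc(-c2nc(C)c3c(c2N)C(=O)N(Cc2ccncc2)C3=O)n1`, 26400 nM

In a physicochemical assay for solubility, using the shake flask method, in simulated intestinal fluid, measured as kinetic solubility, with a stated time of 2 h, at 25 degrees C, at pH 6.5 (a higher number here means a more soluble compound, a lower number a less soluble compound), compound 1 gives 23800 nM and compound 2 gives 26400 nM; the two values sit within the usual scatter of one another, so neither stands apart from the other. Compound 3 `Cc1noc(-c2nc(C)c3c(c2N)C(=O)N(Cc2ccc(CO)cc2)C3=O)n1` has not yet been measured in this assay. It differs from compound 1 in one place: hydroxymethyl in place of 4-fluorophenoxy on an aromatic carbon. For the measured compounds named here, no step between measured compounds covers a change of this kind, so the expectation rests on compound 1 alone. Compound 3 is expected to gain in this assay beyond the scatter, a step of a 2.7-fold higher number from compound 1 to compound 3 (0.44 log units; beyond the scatter). For compound 3 the estimated value is 65000 nM, with a range from 25000 nM to 170000 nM.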

Compound 3, solubility: < 5000 nM
Compound 3 ended at the assay's limit; the forecaster's own chance of this, stated with the estimate: 10%; middle value at least 13-fold (1.11 log units) from the limit.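

In this assay, compound 3 reads only as a limit of the assay, not as a number: the limit of < 5000 nM in this assay, at which 1 of the 3 values shown sits. Compound 1 and compound 2 had stayed within the scatter of each other, whereas hydroxymethyl in place of 4-fluorophenoxy on an aromatic carbon brings an at least 4.7-fold lower number from compound 1 to compound 3 (0.67 log units; beyond the scatter). Likewise, 4-(hydroxymethyl)phenyl in place of pyridin-4-yl on a saturated chain carbon brings an at least 5.2-fold lower number from compound 2 to compound 3 (0.72 log units; beyond the scatter). On these data alone, the exact size of both steps stays open. So does whether an amine or a carboxylic acid in place of hydroxymethyl on that aromatic carbon would give a similar result.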